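The source may report more compounds than this note shows. Statements on the series, on what has been measured and on what is new or still open speak of the compounds shown alone.

For the measured compounds named here, compound 3, `Oc1cccc(-c2cc(-c3cccnc3)cc(-c3ccccc3O)n2)c1`, gives 6230 nM in a functional assay on T47D cells (Homo sapiens) for cytotoxicity, read by CCK-8 assay (a higher number here means a weaker inhibitor, a lower number a stronger inhibitor), the highest of the three numbers measured so far. Compound 1, `Oc1ccc(-c2cc(-c3ccsc3)cc(-c3cccc(O)c3)n2)cc1`, gives 760 nM, and compound 2, `Oc1ccc(-c2cc(-c3ccccn3)cc(-c3cccc(O)c3)n2)cc1`, gives 980 nM. Going by the values given here, the one measured step, a 1.3-fold higher number from compound 1 to compound 2 (0.11 log units; within the scatter), exchanges a group at a different position from the change now in question, so it offers no direct guide to it.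

Compound 4, `Oc1ccc(-c2cc(-c3cccnc3)cc(-c3cccc(O)c3)n2)cc1`, differs from compound 3 in one place: 4-hydroxyphenyl in place of 2-hydroxyphenyl on an aromatic carbon. Among the compounds with values here, no measured pair isolates this swap, so the expectation rests instead on the pattern that compounds 1 and 2, which both carry a 4-hydroxyphenyl and a 3-hydroxyphenyl group on the shared core, sit well below compound 3. Compound 4 shares that arrangement, so a step down toward their range is expected for the move from compound 3 to compound 4, of about a 5.7-fold lower number from compound 3 to compound 4 (0.75 log units; beyond the scatter). Compound 4 is therefore estimated at 1100 nM, with a range from 450 nM to 2800 nM.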

Compound 4, half-maximal inhibitory concentration: > 50000 nM
Compound 4: no number, only a limit; the forecaster's own chance of this, stated with the estimate: 3%; middle value at least 45-fold (1.65 log units) from the limit.
By their numbers in this assay, from the lowest: compounds 1 and 2 (each within the scatter of the next); then compound 3. At a limit, above all of these: compound 4.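

In this assay, compound 4 has no number, only a limit: the limit of > 50000 nM in this assay, at which 1 of the 4 values shown sits. Putting 4-hydroxyphenyl in place of 2-hydroxyphenyl, on the carbon next to the ring nitrogen, gives an at least 8.0-fold higher number from compound 3 to compound 4 (0.90 log units; beyond the scatter), so with the same atoms, the way the hydroxyphenyl group is joined matters here. The pyridine position proves just as sensitive: pyridin-3-yl in place of pyridin-2-yl gives an at least 51-fold higher number from compound 2 to compound 4 (1.70 log units; beyond the scatter), and pyridin-3-yl in place of thiophen-3-yl gives an at least 65-fold higher number from compound 1 to compound 4 (1.81 log units; beyond the scatter), although the exchange between those last two groups gave only a 1.3-fold higher number from compound 1 to compound 2 (0.11 log units; within the scatter).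

On these data alone, because of the limit, the true size of all three steps stays unknown. Also open, as far as these compounds go, is how 3-hydroxyphenyl at the place of the changed hydroxyphenyl group, or a methoxyphenyl or aminophenyl group there, would read in this assay.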